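Branched amide series: methyl added on a chain carbon

The compounds below may be only part of what the source reports. "The series", "measured", "known", "first", "only" and "open" are said of these compounds alone.

Compound 1 `CCCC(C(N)=O)C(C)C` serves as the reference point of the series. In a functional assay on the whole organism (Spinal nerve) with Rattus norvegicus as the target (a lower number here means that less compound is needed, a higher number that more compound is needed for the effect), compound 1 gives 42 mg/kg. Among the two numbers available this is the lowest, and the nearest is compound 2 `CCC(C)C(CC)C(=O)NC(N)=O`: in this assay compound 2 gives 49 mg/kg, which lies within the scatter of the number for compound 1, so the two cannot be ordered. Going by the values given here, no pair of measured compounds differs in a single place, so no measured step is available to calibrate what one small change does here.

Compound 3 `CCC(C)C(C(N)=O)C(C)C` is the next compound to be measured. It differs from compound 1 by methyl in place of hydrogen on a saturated chain carbon bound to two saturated chain carbons. The change is a small addition of saturated carbon on the branched chain of the amide, with the amide itself unchanged.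

Among the compounds with values here, with no measured step to lean on, the expected step of a 1.1-fold higher number from compound 1 to compound 3 (0.03 log units; within the scatter) is small, with no preferred direction, and is not expected to exceed the usual scatter. For compound 3 in this assay the expected value is 45 mg/kg, with a range from 20 mg/kg to 100 mg/kg.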

Compound 3, dose for half-maximal effect: 50 mg/kg
Compound 3: middle estimate off by 1.1-fold (0.05 log units), on the low side; the range from low to high includes it.
By their numbers in this assay, from the lowest: compounds 1, 2 and 3 (each within the scatter of the next).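

Going by these compounds alone, this is the first step that can be read at a single place: in this assay, methyl in place of hydrogen on a saturated chain carbon bound to two saturated chain carbons gives a 1.2-fold higher number from compound 1 to compound 3 (0.08 log units; within the scatter) and so compound 1 and compound 3 cannot be ordered. Within the data shown here, the series now has one measured calibration for a small addition of saturated carbon on the chain, and at this position that addition is not resolved by the assay, whereas the earlier compounds offered no single-place comparison at all. Nothing available bears on the reason for this outcome, and this single step describes only this one position and this one group.

As far as these compounds go, whether a longer chain, a phenyl group or a hydroxyl group on this same carbon would give a step beyond the scatter remains open. Also open, from the compounds shown here alone, is whether a step beyond the scatter would follow from replacing the primary amide of compound 1 with a carboxylic acid or an amine, since the amide is unchanged in this pair.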